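This account rests on a few compounds, and the source may have more. Where it says the series, first, only, none or still open, it means among the compounds named here.

In a functional assay on PC-3 cells (Homo sapiens) for cytotoxicity, read by MTT assay, with a stated time of 48 h (a lower number here means a stronger inhibitor, a higher number a weaker inhibitor), compound 2 `COc1cc(-c2nnc3n2NC(c2ccco2)C(C(=O)c2cccs2)S3)cc(OC)c1OC` gives 46200 nM. Compound 3 `COc1cccc(C(=O)C2Sc3nnc(-c4cc(OC)c(OC)c(OC)c4)n3NC2c2ccco2)c1` gives 84600 nM. Compound 1 `COc1ccc(C(=O)C2Sc3nnc(-c4cc(OC)c(OC)c(OC)c4)n3NC2c2cccs2)cc1` gives 95900 nM.

Compound 2 holds the lowest of the three numbers, though compound 3 sits within the scatter of it and only compound 1 lies beyond it. Compound 4 `COc1cc(-c2nnc3n2NC(c2ccco2)C(C(=O)c2ccc([N+](=O)[O-])cc2)S3)cc(OC)c1OC` differs from compound 2 at one place: 4-nitrophenyl in place of thiophen-2-yl on a carbonyl carbon. Among the measured compounds shown here, the only measured step at the carbonyl carbon is a 1.8-fold higher number from compound 2 to compound 3 (0.26 log units; within the scatter), and it stayed within the scatter. Nothing measured here distinguishes a nitro-bearing ring from the other carbonyl substituents. For compound 4 the expected change is therefore a 1.3-fold higher number from compound 2 to compound 4 (0.11 log units; within the scatter), with no step beyond the scatter anticipated. Compound 4 is estimated at 60000 nM, within a range from 25000 nM to 140000 nM.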

Compound 4, half-maximal inhibitory concentration: 27900 nM
The estimate for compound 4 lay 2.2-fold (0.33 log units) above the measured number, and the stated range covers the measured number.
By their numbers in this assay, from the lowest: compounds 4, 2, 3 and 1 (each within the scatter of the next, the first and the last beyond it).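

In this assay, a change at this carbonyl carbon now produces a step beyond the scatter, if only a modest one: a 3.0-fold lower number from compound 3 to compound 4 (0.48 log units; beyond the scatter). Against thiophen-2-yl the 4-nitrophenyl group shows no separation, with a 1.7-fold lower number from compound 2 to compound 4 (0.22 log units; within the scatter), so the difference appears only against 3-methoxyphenyl. The data shown offer no measured explanation for this step.

As far as these compounds go, it remains open how a plain phenyl ring would read at this carbonyl carbon. From the compounds shown here alone, it is also open whether an amine or a carboxylic acid in place of the nitro group would keep the lower number.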